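This account rests on a few compounds, and the source may have more. Where it says the series, first, only, none or still open, it means among the compounds named here.

Working notes on the series. Compound 1 `COC(=O)N(Cc1cccc(F)c1)c1c(N)nc(-c2nn(Cc3ccccc3F)c3ncccc23)nc1N` is the reference point; in an assay on cells for activation of Guanylate cyclase soluble subunit alpha-1 (Rattus norvegicus), read by cGMP accumulation and immunoassay, with a stated time of 10 min (a lower number here means that less compound is needed, a higher number that more compound is needed for the effect), compound 1 gives 0.2 uM. Going by the values given here, compound 2 `COC(=O)N(Cc1ccc(F)cc1)c1c(N)nc(-c2nn(Cc3ccccc3F)c3ncccc23)nc1N` gives 0.7 uM in this assay, and the one measured step in the set is a 3.5-fold higher number from compound 1 to compound 2 (0.54 log units; beyond the scatter). Compound 3 `Nc1nc(-c2nn(Cc3ccccc3F)c3ncccc23)nc(N)c1NC(=O)OC1CCC1` gives 0.2 uM in this assay: level with compound 1 at the digits shown, the two together the lowest of the three numbers, with compound 2 the furthest away.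

Compound 4 `Nc1nc(-c2nn(Cc3ccccc3F)c3ncccc23)nc(N)c1N1C[C@H](C(F)(F)F)OC1=O` is not yet measured. Relative to compound 3 the change is a group of 10 heavy atoms (4 carbon, 1 nitrogen, 2 oxygen, 3 fluorine; one five-membered non-aromatic ring with 2 hetero atoms) in place of a group of 8 heavy atoms (5 carbon, 1 nitrogen, 2 oxygen; one four-membered non-aromatic ring of carbon only), on an aromatic carbon. Among the compounds with values here, the single measured step, from compound 1 to compound 2, concerns the group on the saturated chain carbon bound to an amide-type nitrogen, not the position changed here, so no measured step bears directly on this change. What compound 1 and compound 3 show is that two different groups at this position give the same number at the digits shown. The step from compound 3 to compound 4 is therefore expected to be small, a 1.5-fold higher number from compound 3 to compound 4 (0.18 log units; within the scatter). For compound 4 the estimate in this assay is 0.3 uM, with a range from 0.08 uM to 1.2 uM.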

Compound 4, minimum effective concentration: 0.2 uM
Compound 4: middle estimate off by 1.5-fold (0.18 log units), on the high side, within the range that was stated.
By their numbers in this assay, from the lowest: compounds 1, 3 and 4 (each within the scatter of the next); then compound 2.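

In this assay, replacing (cyclobutyloxycarbonyl)amino with the five-membered ring bearing trifluoromethyl gives no change at the digits printed from compound 3 to compound 4 (within the scatter). At this aromatic carbon, ortho to two amino groups, the number therefore holds across a larger group with a defined stereocentre, a different ring and 0 hydrogen-bond donors in place of 1, so the hydrogen-bond donor of the group that leaves is not required to hold this number in this pair. No measured evidence in the set accounts for this outcome.

On these data alone, whether the opposite configuration at the stereocentre, or a methyl group in place of trifluoromethyl, would hold the same number remains open. Also open, as far as these compounds go, is how far the position tolerates groups of another kind, such as a carboxylic acid or a plain dimethylamine on this aromatic carbon.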